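The source may report more compounds than this note shows. Statements on the series, on what has been measured and on what is new or still open speak of the compounds shown alone.

Measured compounds and values:
- compound 1, `CCOc1ccc(-n2cnc3cnc(-c4ccc(F)cc4C)cc32)cc1`: 0.97
- compound 2, `Cc1ccc(-n2cnc3cnc(-c4ccc(F)cc4C)cc32)cc1`: "not determined" (no result reported)

Two compounds of the series have been run in an ADME assay on S9 fraction from liver (Mus musculus) for metabolic stability, read by LC-MS, using NADPH, with a stated time of 45 min, tested at 3 uM, in the presence of a further agent that is not named here; on this read-out higher numbers stand for higher hepatic extraction and lower numbers for lower hepatic extraction. Compound 1 gives 0.97 in this assay, a value at the high end of the fraction. Compound 2 differs from compound 1 in that the ethoxy is replaced by a methyl on the same ring. For the measured compounds named here, compound 2 gives "not determined" (no result reported) in this assay, so no single number stands for it, and no step between measured compounds can be drawn.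

The step under consideration goes from compound 2 to compound 3, `Cc1cc(F)ccc1-c1cc2c(cn1)ncn2-c1ccc(S(C)(=O)=O)cc1`. The change is methylsulfonyl in place of methyl on an aromatic carbon. In words: methylsulfonyl in place of methyl on an aromatic carbon.

With compound 2 undetermined, the step cannot be anchored to its starting value, and only the reading of compound 1 in this assay offers a reference point. The expectation is that compound 3 will lie below compound 1 by more than the scatter, though the direction rests on a single measured value. Compound 3 is estimated at 0.6 in this assay, with a range from 0.3 to 0.9.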

Compound 3, hepatic extraction ratio: 0.07
Compound 3: middle estimate off by 0.53, on the high side; the whole stated range lies above it.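

In this assay the substituent on the aromatic carbon para to a large group now proves able to move the read-out: methylsulfonyl in place of ethoxy shifts it by a number 0.90 lower from compound 1 to compound 3 (beyond the scatter) with the rest of the core unchanged. Compound 1 alone gave only the high end of the fraction, whereas compound 3 at 0.07 places the low end on the same core, so this single place spans almost the whole scale for this pair. No measurement at hand accounts for the size of the step, which therefore stands as an observation on these two compounds only.

On these data alone, the step from compound 2 to compound 3 cannot be read, since compound 2 carries no number, and it stays open whether methyl at this place would sit closer to ethoxy or to methylsulfonyl. Also open, as far as these compounds go, is whether the low value is particular to methylsulfonyl or would appear with other groups at this place, such as an amine, a carboxylic acid or a longer alkoxy chain.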